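Adding a Methoxy to the Core Phenyl of Compound 2

The source may hold more compounds than are shown below. What is called first, only, known or untested is meant among the compounds shown, and "the series" means these compounds.

Compound 2 `COc1cc(Cn2cc(CNC(=O)c3cn(-c4ccccc4)nc3-c3ccccc3)nn2)cc(OC)c1` stands highest of the two numbers recorded in a functional assay on MCF7 cells (Homo sapiens) for antiproliferative activity, read by sulforhodamine B assay, with a stated time of 48 h (on this read-out higher numbers stand for weaker inhibition of growth and lower numbers for stronger inhibition of growth), where compound 2 gives 2400 nM. Going by the values given here, compound 1 `O=C(NCc1cn(Cc2ccc(C(F)(F)F)cc2)nn1)c1cn(-c2ccccc2)nc1-c1ccccc1` gives 840 nM, and the step of a 2.9-fold higher number from compound 1 to compound 2 (0.46 log units; beyond the scatter) is the only one between two plain numbers. Compound 3 `COc1cc(Cn2cc(CNC(=O)c3cn(-c4ccccc4)nc3-c3ccccc3)nn2)cc(OC)c1OC` reaches only the limit > 100000 nM in this assay. Compound 4 `COc1ccc(-c2nn(-c3ccccc3)cc2C(=O)NCc2cn(Cc3cc(OC)cc(OC)c3)nn2)cc1` differs from compound 2 in one place: methoxy in place of hydrogen on an aromatic carbon. Among the compounds with values here, the one measured step of the same kind, an at least 41-fold higher number from compound 2 to compound 3 (1.61 log units; beyond the scatter), was also a methoxy in place of hydrogen on an aromatic carbon, but at another place, on the aromatic ring held by the saturated chain carbon bound to an aromatic nitrogen, not on the phenyl of the core; the step of an at least 110-fold higher number from compound 1 to compound 3 (2.07 log units; beyond the scatter) points the same way. These steps bear on compound 4 only loosely, and a weakening in this assay is expected, probably smaller than those large ones. Compound 4 is therefore estimated at about 5000 nM. Its expected range runs from 1500 nM to 30000 nM. That amounts to an expected step of a 2.1-fold higher number from compound 2 to compound 4 (0.32 log units; beyond the scatter).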

Compound 4, concentration for 50% growth inhibition: 700 nM
Compound 4: the middle estimate sits 7.1-fold (0.85 log units) above what was measured; measured number outside the range, below it.
By their numbers in this assay, from the lowest: compounds 4 and 1 (each within the scatter of the next); then compound 2. At a limit, above all of these: compound 3.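

On the phenyl of the core, para to a large group, the change from phenyl to 4-methoxyphenyl gives a 3.4-fold lower number from compound 2 to compound 4 (0.54 log units; beyond the scatter) in this assay, so here a methoxy in place of hydrogen strengthens growth inhibition. The same exchange on the other aromatic ring went the opposite way, an at least 41-fold higher number from compound 2 to compound 3 (1.61 log units; beyond the scatter), so within these two steps the outcome depends on which ring carries the methoxy. The value of compound 3 is a limit, not a number: the limit of > 100000 nM in this assay, at which 1 of the 4 values shown sits.

The compounds shown leave open whether a hydroxy group or a chlorine atom at this place would act as the methoxy does, and whether the methoxy would bring the same gain alongside the 4-(trifluoromethyl)phenyl of compound 1. They also give no explanation for why the two rings respond in opposite directions.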